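The compounds below may be only part of what the source reports. "The series", "measured", "known", "first", "only" and "open" are said of these compounds alone.

In a functional assay on MDA-MB-231 cells (Homo sapiens) for inhibition, read by MTT assay, with a stated time of 72 h (a higher number here means a weaker inhibitor, a lower number a stronger inhibitor), compound 1 (`Nc1ncnc2c1c(-c1cnc3[nH]ccc3c1)nn2CC(=O)NO`) gives > 150000 nM, which is a limit of the assay and not a number. Compound 2 (`Nc1ncnc2c1c(-c1cnc3[nH]ccc3c1)nn2CCCCC(=O)NO`) gives > 50000 nM, also a limit, so it has no measured potency and stands only at this bound. Compound 3 (`Nc1ncnc2c1c(-c1cnc3[nH]ccc3c1)nn2CCCCCCCCCC(=O)NO`) keeps the shared core and extends the chain: 5-(hydroxycarbamoyl)pentyl in place of hydroxycarbamoyl on a saturated chain carbon, four bonds along the chain from an aromatic nitrogen. Thus 5-(hydroxycarbamoyl)pentyl takes the place of hydroxycarbamoyl on a saturated chain carbon, four bonds along the chain from an aromatic nitrogen. Among the measured compounds shown here, the only measured step that bears on this change is a step that the two limits leave unreadable from compound 1 to compound 2, and it provides no size to carry forward. The expectation is therefore tentative, with a modest move toward stronger inhibition estimated as an at least 4.1-fold lower number from compound 2 to compound 3 (0.61 log units; beyond the scatter). Another limit would not be surprising. For compound 3 the estimated value in this assay is 12000 nM, with an expected range of 1500 nM to 60000 nM.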

Compound 3, half-maximal inhibitory concentration: 10100 nM
The estimate for compound 3 lay 1.2-fold (0.07 log units) above the measured number, and the stated range covers the measured number.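

Among the compounds shown here, compound 3 is the only one of the three compounds with a measured number rather than a limit in this assay, so this position now carries a step whose size can be read at least in part. With 5-(hydroxycarbamoyl)pentyl in place of hydroxycarbamoyl on a saturated chain carbon, four bonds along the chain from an aromatic nitrogen, the result is an at least 4.9-fold lower number from compound 2 to compound 3 (0.69 log units; beyond the scatter), whereas the earlier step between the two limits cannot be read. This size is only a lower bound, and compound 2 gives a limit and not a number: the limit of > 50000 nM in this assay, at which 1 of the 3 values shown sits.

From the compounds shown here alone, whether a longer chain would lower the number further, leave it unchanged or raise it remains open. Going by these compounds, it is equally open how a carboxylic acid or an amine in place of the hydroxycarbamoyl group would read on this chain.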